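The compounds below may be only part of what the source reports. "The series", "measured", "known", "first", "only" and "open" are said of these compounds alone.

Compound 1, `CCCCSc1nc2c(N)ncnc2n1[C@@H]1O[C@H](COP(=O)(O)OP(=O)(O)OP(=O)(O)O)[C@@H](O)[C@H]1O`, in an assay on isolated protein for inhibition of ectonucleoside triphosphate diphosphohydrolase 1 (Homo sapiens), read by malachite green, with stated times of 3 min and 15 min (a higher number here means a weaker inhibitor, a lower number a stronger inhibitor), gives 5600 nM.
Compound 2, `CCCCSc1nc2c(N)ncnc2n1[C@@H]1O[C@H](COP(=O)(O)OP(=O)(O)O)[C@@H](O)[C@H]1O`, in this assay gives 28000 nM.

Going by the values given here, of the two measured compounds, compound 2 gives the higher number in this assay, its only neighbour being compound 1, separated by a 5.0-fold higher number from compound 1 to compound 2 (0.70 log units; beyond the scatter). Compound 3, `CCCCSc1nc2c(N)ncnc2n1[C@@H]1O[C@H](COP(=O)(O)O)[C@@H](O)[C@H]1O`, is the next member of the series: it differs from compound 2 by a hydrogen atom in place of a group of 4 heavy atoms (3 oxygen, 1 phosphorus; no ring), on an oxygen. Among the compounds with values here, only one measured step bears on this change, a 5.0-fold higher number from compound 1 to compound 2 (0.70 log units; beyond the scatter), in which a group of the same kind was removed from the same sort of oxygen. Compound 3 now loses a further such group. On that single precedent the number is expected to rise again, toward weaker inhibition, by an amount at least comparable to the earlier step, though one step is a thin basis and the spread must be wide. Compound 3 is therefore estimated at 150000 nM in this assay, within 40000 nM to 500000 nM, an expected step of a 5.4-fold higher number from compound 2 to compound 3 (0.73 log units; beyond the scatter).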

Compound 3, half-maximal inhibitory concentration: 35000 nM
The estimate for compound 3 lay 4.3-fold (0.63 log units) above the measured number; the whole stated range lies above it.
By their numbers in this assay, from the lowest: compound 1; then compounds 2 and 3 (each within the scatter of the next).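

In this assay, a second replacement of a group of 4 heavy atoms (3 oxygen, 1 phosphorus) by a hydrogen atom, on an oxygen whose other neighbours are phosphorus, gives a 1.3-fold higher number from compound 2 to compound 3 (0.10 log units; within the scatter), so it does not repeat the earlier 5.0-fold higher number from compound 1 to compound 2 (0.70 log units; beyond the scatter). The same kind of change therefore need not count equally at each stage of shortening this chain of phosphorus-bearing groups: taken together, the two replacements give a 6.3-fold higher number from compound 1 to compound 3 (0.80 log units; beyond the scatter), and among these compounds the difference beyond the scatter appears only at the first replacement. Nothing measured here explains this difference between the two stages.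

The compounds shown leave open what happens when the phosphorus-bearing group still present in compound 3 gives way to a plain hydroxyl. They also leave open how a carboxylic acid or an amine would compare in its place.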